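The compounds below may be only part of what the source reports. "The series", "measured", "known", "first", "only" and "open" are said of these compounds alone.

Working notes on the series. Compound 1 `CN(C(=O)NC(=O)c1ccccc1F)c1nc(C(F)(F)F)c(C(=O)N/N=C/c2ccccc2C(F)(F)F)s1` and compound 3 `CN(C(=O)NC(=O)c1ccccc1F)c1nc(C(F)(F)F)c(C(=O)N/N=C/c2ccc(C(F)(F)F)cc2)s1` share a core; the two differ by 4-(trifluoromethyl)phenyl in place of 2-(trifluoromethyl)phenyl on a carbon with a double bond to nitrogen. In a functional assay on BCG823 cells (Homo sapiens) for inhibition, read by MTT assay, with a stated time of 72 h (a higher number here means a weaker inhibitor, a lower number a stronger inhibitor), compound 1 gives 4.67 ug/mL. In this assay compound 3 gives 3.87 ug/mL, a step of a 1.2-fold lower number from compound 1 to compound 3 (0.08 log units; within the scatter). Compound 2 `CNc1nc(C(F)(F)F)c(C(=O)N/N=C/c2ccccc2C(F)(F)F)s1` is compound 1 after the change (hydrogen in place of ((2-fluorophenyl)carbonyl)carbamoyl on a nitrogen on an aromatic ring). In this assay compound 2 gives only a limit, > 100 ug/mL. The step of an at least 21-fold higher number from compound 1 to compound 2 (1.33 log units; beyond the scatter) is therefore read against the limit of > 100 ug/mL in this assay, at which 1 of the 3 values shown sits, rather than as a number. Compound 4 `CNc1nc(C(F)(F)F)c(C(=O)N/N=C/c2ccc(C(F)(F)F)cc2)s1` is the unmeasured partner: from compound 3 it differs by hydrogen in place of ((2-fluorophenyl)carbonyl)carbamoyl on a nitrogen on an aromatic ring, the same change as from compound 1 to compound 2, in the same place. Because the measured instance of this change gave an at least 21-fold higher number from compound 1 to compound 2 (1.33 log units; beyond the scatter), the step from compound 3 to compound 4 is expected to be of the same kind and of similar size, a 39-fold higher number from compound 3 to compound 4 (1.59 log units; beyond the scatter), ending at the limit as well. Compound 4 is thus estimated at 150 ug/mL in this assay, with the expectation that only a limit is reported.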

Compound 4, half-maximal inhibitory concentration: > 100 ug/mL
Compound 4 gave a limit, no number; the forecaster's own chance of this, stated with the estimate: 80%; the middle value lies beyond the limit too.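

In this assay, hydrogen in place of ((2-fluorophenyl)carbonyl)carbamoyl on the core of compound 3 again gives a large step, an at least 25-fold higher number from compound 3 to compound 4 (1.41 log units; beyond the scatter). The change therefore goes the same way on both cores shown, which supports carrying its direction from one to the other in this pair, but not a close comparison of its size: the same change on two cores in this assay, an at least 21-fold higher number (1.33 log units; beyond the scatter) from compound 1 to compound 2 and an at least 25-fold higher number (1.41 log units; beyond the scatter) from compound 3 to compound 4; the limit leaves it open whether they differ. Compound 4 gives only a limit, > 100 ug/mL, not a number, so the full size of this step remains unread: the limit of > 100 ug/mL in this assay, at which 2 of the 4 values shown sit.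

The compounds shown compare only the whole ((2-fluorophenyl)carbonyl)carbamoyl group with hydrogen, so it remains open which part of that group is needed. A simple acetyl group or an unsubstituted benzoyl urea on the same nitrogen could separate these parts, and an amine or a longer chain in place of the trifluoromethyl-bearing phenyl would test the change on a further core.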